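This account rests on a few compounds, and the source may have more. Where it says the series, first, only, none or still open, it means among the compounds named here.

Compound 1 `CCCn1c(=O)n(C)c(=O)c2c1ncn2CCC(=O)O`: in an assay on Cerebral cortex for binding affinity to adenosine receptor A1 (Cavia porcellus), read by radioligand binding (a lower number here means a stronger inhibitor, a higher number a weaker inhibitor), compound 1 gives > 200000 nM, a limit of the assay.
Compound 2 `CCCn1c(=O)n(C)c(=O)c2c1ncn2CCC#N`: in this assay compound 2 gives 88600 nM.
Compound 3 `CCCn1c(=O)n(C)c(=O)c2c1ncn2CCN(C)C`: in this assay compound 3 gives > 200000 nM, a limit of the assay.

Compound 3 therefore sits at the limit of > 200000 nM in this assay, at which 2 of the 3 values shown sit, and the comparison with compound 1 is left open: a step that the two limits leave unreadable from compound 1 to compound 3. Against compound 2 the step reads an at least 2.2-fold higher number from compound 2 to compound 3 (0.35 log units; beyond the scatter). Compound 4 `CCCn1c(=O)n(C)c(=O)c2c1ncn2CCCO` differs from compound 3 by hydroxymethyl in place of dimethylamino on a saturated chain carbon, two bonds along the chain from an aromatic nitrogen. The two measured steps, an at least 2.2-fold lower number from compound 1 to compound 2 (0.35 log units; beyond the scatter) and an at least 2.2-fold higher number from compound 2 to compound 3 (0.35 log units; beyond the scatter), show that of the three groups at this chain position only cyano moved the number below the limit. Compound 4 is therefore expected to stay near the limit, with a step of about an at least 1.3-fold lower number from compound 3 to compound 4 (0.12 log units; that floor lies within the scatter). The estimate for compound 4 is 150000 nM, within 50000 nM to 400000 nM.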

Compound 4, inhibition constant: 112000 nM
For compound 4 the middle estimate is 1.3-fold (0.13 log units) above the measured one, within the range that was stated.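

In this assay, for the compounds shown here, cyano is no longer the only group at this position to give a readable number: the step to hydroxymethyl is a 1.3-fold higher number from compound 2 to compound 4 (0.10 log units; within the scatter), so these two groups cannot be told apart. The steps of an at least 1.7-fold lower number from compound 3 to compound 4 (0.25 log units; that floor lies within the scatter) and an at least 1.7-fold lower number from compound 1 to compound 4 (0.25 log units; that floor lies within the scatter) have floors within the scatter, so neither establishes a real gain. Compound 1 and compound 3 remain at a limit of the assay: the limit of > 200000 nM in this assay, at which 2 of the 4 values shown sit.

On these data alone, whether a primary amine, an amide, a methyl ether or a longer chain would lower the number stays open. So does how far beyond that limit compound 1 and compound 3 lie.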